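A few compounds are considered here, and "the series" means these few. Any claim that something is new, unique, unknown or untested is made for them only; others in the source may bear on it.

Measured compounds:
- compound 1, `Cc1ccc(C2=Nn3c(nnc3C(C)c3ccc(CC(C)C)cc3)SC2)cc1`: 7300 nM
- compound 2, `CC(C)Cc1ccc(C(C)c2n[nH]c(=S)n2N)cc1`: "not active" (no number reported)
- compound 3, `CC(c1ccc(-c2ccccc2)c(F)c1)c1nnc2n1N=C(c1ccc(Cl)cc1Cl)CS2`: 8600 nM

In a functional assay on HepG2 cells (Homo sapiens) for inhibition, read by sulforhodamine B assay, with a stated time of 72 h (a higher number here means a weaker inhibitor, a lower number a stronger inhibitor), compound 3 gives 8600 nM, and in the same assay compound 1 gives 7300 nM. These two numbers lie within the scatter of each other, so neither can be called the stronger inhibitor. Compound 2, which lacks the fused bicyclic part of the shared core, returned "not active" (no number reported), with no single number reported, so it gives no measure of size for comparison.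

Compound 4, `CC(c1ccc(-c2ccccc2)c(F)c1)c1nnc2n1N=C(c1ccc(Cl)cc1)CS2`, has not yet been measured. It differs from compound 3 in one place: hydrogen in place of chloro on an aromatic carbon. For the measured compounds named here, no pair of measured compounds differs by this change alone, so the data give no direct step to lean on; the only anchors are the values of compound 3 and compound 1 in this assay, which are close to each other.

The step from compound 3 to compound 4 is therefore expected to be small, a 1.3-fold higher number from compound 3 to compound 4 (0.11 log units; within the scatter), not clearly beyond the scatter, leaning if anything toward a slightly weaker inhibitor. Compound 4 is estimated to give 11000 nM in this assay, with a range from 4000 nM to 30000 nM.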

Compound 4, half-maximal inhibitory concentration: 6700 nM
Compound 4: middle estimate off by 1.6-fold (0.22 log units), on the high side; the range from low to high includes it.
By their numbers in this assay, from the lowest: compounds 4, 1 and 3 (each within the scatter of the next).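

In this assay, for the compounds shown here, the exchange of 2,4-dichlorophenyl for 4-chlorophenyl gives a 1.3-fold lower number from compound 3 to compound 4 (0.11 log units; within the scatter) and is the only step here that isolates a single place. It shows that hydrogen in place of chloro, on an aromatic carbon ortho to a large group and meta to a chloro group, leaves a reading that cannot be told apart from the original one in this assay, so the number does not depend measurably on this chloro group when the rest of the molecule stays the same. No measured finding is at hand to account for this result.

The compounds shown leave open whether the remaining chloro group of compound 4 can also give way to hydrogen with as small a step, and whether the two chloro groups together matter more than either one alone. They also leave open whether another group at the same aromatic carbon, such as a methoxy group, an amine or a carboxylic acid, would move the number beyond the scatter in either direction.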